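The source may hold more compounds than are shown below. What is called first, only, known or untested is meant among the compounds shown, and "the series" means these compounds.

Measured in a functional assay on KB-VIN10 cells (Homo sapiens) for inhibition, with a stated time of 72 h; a higher number here means a weaker inhibitor, a lower number a stronger inhibitor:
- compound 1 `COc1ccc(S(=O)(=O)N2CCc3cccc(-c4ccc(F)nc4)c32)cc1`: 151 nM
- compound 2 `COc1ccc(S(=O)(=O)N2CCc3cccc(-c4ccc(F)cc4)c32)cc1`: 94.6 nM

Among the measured compounds shown here, only these two compounds have numbers so far, and compound 2 sits level with compound 1 within the scatter of repeat measurements. Compound 3 `COc1ccc(-c2cccc3c2N(S(=O)(=O)c2ccc(OC)cc2)CC3)cc1` has not yet been measured. It has methoxy in place of fluoro on an aromatic carbon, para to a large group, so 4-fluorophenyl becomes 4-methoxyphenyl: methoxy in place of fluoro on an aromatic carbon.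

For the measured compounds named here, no measured step makes this exact swap. The closest one, a 1.6-fold lower number from compound 1 to compound 2 (0.20 log units; within the scatter), changes the same aryl group, replacing 6-fluoropyridin-3-yl with 4-fluorophenyl, and it stays within the scatter. That single step is thin evidence, but it gives no reason to expect a shift beyond the scatter in this assay, in either direction. The estimated change is a 1.1-fold lower number from compound 2 to compound 3 (0.02 log units; within the scatter). For compound 3 the expected value is 90 nM, with an estimated range of 30 nM to 270 nM.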

Compound 3, half-maximal inhibitory concentration: 352 nM
The estimate for compound 3 lay 3.9-fold (0.59 log units) below the measured number, and the stated range ends below it.
By their numbers in this assay, from the lowest: compounds 2 and 1 (each within the scatter of the next); then compound 3.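

In this assay, among the compounds shown here, methoxy in place of fluoro, turning 4-fluorophenyl into 4-methoxyphenyl, gives a 3.7-fold higher number from compound 2 to compound 3 (0.57 log units; beyond the scatter), the first step at this position to lie beyond the scatter. Going from 6-fluoropyridin-3-yl to 4-methoxyphenyl gives a 2.3-fold higher number from compound 1 to compound 3 (0.37 log units; beyond the scatter), so compound 3 is the weakest of the three, while the two fluoro compounds stay within the scatter of each other. Nothing shown here explains why methoxy gives the higher number.

Going by these compounds, it remains open whether this loss is particular to methoxy or would also appear with another group in its place, such as chloro, hydroxyl or an amine. With only one example of this swap, the compounds shown also cannot tell whether methoxy would give a similar step on the pyridine ring.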